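The source may report more compounds than this note shows. Statements on the series, on what has been measured and on what is new or still open speak of the compounds shown alone.

Working notes on the series. Among the measured compounds shown here, compound 1 `CC(C)C[C@@H](NC(=O)OC(C)(C)C)C(=O)Nc1ccc(O)c2c(=O)cc(-c3ccccc3Cl)oc12` and compound 2 `CSCC[C@@H](NC(=O)OC(C)(C)C)C(=O)Nc1ccc(O)c2c(=O)cc(-c3ccccc3Cl)oc12` are the two measured members. In a functional assay on ID8 cells (Mus musculus) for antiproliferative activity (on this read-out lower numbers stand for stronger inhibition and higher numbers for weaker inhibition), compound 1 gives 17000 nM and compound 2 gives 13000 nM on the same read-out. For the measured compounds named here, the one measured step, a 1.3-fold lower number from compound 1 to compound 2 (0.12 log units; within the scatter), exchanges isopropyl for (methylsulfanyl)methyl on a saturated chain carbon. Compound 2 therefore stands level with compound 1, and no order can be drawn between them.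

Compound 3 `CSCC[C@H](NC(=O)OC(C)(C)C)C(=O)Nc1ccc(O)c2c(=O)cc(-c3ccccc3Cl)oc12` is the next entry, and the change from compound 2 is the two compounds have the same atoms and bonds and differ only in configuration as drawn: 1 of 1 stereo elements differ; a stereocentre at a saturated chain carbon is drawn R in compound 2 and S in compound 3 and nothing else. The stereocentre at a saturated chain carbon is drawn R in compound 2 and S in compound 3. Going by the values given here, no measured pair differs in configuration, so the only step available bears on the side chain and gives no direct measure of this change. With so little to go on, no shift beyond the scatter is expected in this assay, and neither direction is favoured, though the range has to stay wide. The expected step is a 1.1-fold higher number from compound 2 to compound 3 (0.03 log units; within the scatter) in this estimate. For compound 3 the estimated value is 14000 nM with an expected range from 6000 nM to 32000 nM on this read-out.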

Compound 3, half-maximal inhibitory concentration: 6200 nM
For compound 3 the middle estimate is 2.3-fold (0.35 log units) above the measured one, and the stated range covers the measured number.
By their numbers in this assay, from the lowest: compound 3; then compounds 2 and 1 (each within the scatter of the next).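

In this assay, among the compounds shown here, the inversion at the saturated chain carbon gives a 2.1-fold lower number from compound 2 to compound 3 (0.32 log units; beyond the scatter), the first step that clears the scatter, though the printed size is modest. For the compounds shown here, the earlier exchange of isopropyl for (methylsulfanyl)methyl on this same carbon, a 1.3-fold lower number from compound 1 to compound 2 (0.12 log units; within the scatter), stayed within the scatter, so the configuration drawn at this carbon is the first change here to register on this read-out. The shift can be assigned to this stereocentre and to nothing else in the structure, because the pair offers no other difference: the fact that compounds 2 and 3 differ only in the configuration as drawn

Going by these compounds, whether the S configuration would lower the number to a similar extent with the isopropyl side chain of compound 1 remains open, as the configurational effect rests on the (methylsulfanyl)methyl side chain alone. Also open, on these data alone, is how this carbon in the S configuration would read out with a side chain ending in an amine or a carboxylic acid, or with a longer chain.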